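From difluoromethyl to trifluoromethyl on the shared core

The compounds below may be only part of what the source reports. "The series", "measured", "known", "first", "only" and "open" are said of these compounds alone.

Of the compounds shown here, two sharing one core have been measured so far. In a functional assay on OCI-Ly10 cells (Homo sapiens) for cytotoxicity, read by CCK-8 assay, with a stated time of 72 h (a lower number here means a stronger inhibitor, a higher number a weaker inhibitor), compound 1 `Cn1cc(NC(=O)c2cnc3ccc(N4CCC[C@@H](N)C4)nn23)c(C(F)F)n1` gives 10700 nM, and compound 2 `Cn1cc(NC(=O)c2cnc3ccc(N[C@@H]4CCCNC4)nn23)c(C(F)F)n1` gives 700 nM. Going by the values given here, the one measured step is a 15-fold lower number from compound 1 to compound 2 (1.18 log units; beyond the scatter). It came with (piperidin-3-yl)amino in place of 3-aminopiperidin-1-yl on an aromatic carbon, and it puts compound 2 at the lower of the two numbers.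

Compound 3 `Cn1cc(NC(=O)c2cnc3ccc(N[C@@H]4CCCNC4)nn23)c(C(F)(F)F)n1` departs from compound 2 by fluoro in place of hydrogen on a saturated chain carbon bound to an aromatic carbon and two fluorine atoms. This is fluoro in place of hydrogen on a saturated chain carbon bound to an aromatic carbon and two fluorine atoms, so difluoromethyl becomes trifluoromethyl. Among the compounds with values here, the measured step concerns a different change, and no measured pair alters the difluoromethyl group, so its large size does not carry over. The value of compound 2, 700 nM, is the only direct anchor for the expectation. In this assay the expected step is a 1.1-fold higher number from compound 2 to compound 3 (0.06 log units; within the scatter), which would be no change beyond the scatter. Compound 3 is estimated at 800 nM, with an expected range from 280 nM to 2300 nM.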

Compound 3, half-maximal inhibitory concentration: 2800 nM
Compound 3: middle estimate off by 3.5-fold (0.54 log units), on the low side, outside the stated range (above it).
By their numbers in this assay, from the lowest: compound 2; then compound 3; then compound 1.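

Going by these compounds alone, the step of a 4.0-fold higher number from compound 2 to compound 3 (0.60 log units; beyond the scatter) in this assay gives the first measured reading on this position, and it lies beyond the scatter. A single fluoro in place of hydrogen on a saturated chain carbon bound to an aromatic carbon and two fluorine atoms therefore changes the number, with the (piperidin-3-yl)amino group held constant, whereas the earlier pair, with its step of a 15-fold lower number from compound 1 to compound 2 (1.18 log units; beyond the scatter), spoke only to how the piperidine is attached. The compounds shown come with no independent measurement that would account for this difference.

The compounds shown leave open whether the change from difluoromethyl to trifluoromethyl would have a similar effect with the 3-aminopiperidin-1-yl group of compound 1, since trifluoromethyl appears here only with the (piperidin-3-yl)amino group. They also leave open what a methyl, an ethyl or a nitrile would do in place of difluoromethyl, and whether any such group would give a lower number than compound 2 at 700 nM.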